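The source may hold more compounds than are shown below. What is called first, only, known or untested is meant among the compounds shown, and "the series" means these compounds.

Compound 1 `CCCCCCCCOC1CC(=O)Nc2c1c(C)nn2-c1ncnc2nc[nH]c12` gives 8 nM in a functional assay on HEK293 cells for agonist activity at G-protein coupled receptor 39 (Homo sapiens), read by scintillation proximity assay and inositol phosphate accumulation, with a stated time of 75 min, in the presence of a further agent that is not named here; a lower number here means that less compound is needed, a higher number that more compound is needed for the effect. Compound 2 `Cc1nn(-c2ncnc3nc[nH]c23)c2c1C(OCc1ccc(F)cc1)CC(=O)N2` gives 1 nM, and compound 3 `Cc1nn(-c2ncnc3nc[nH]c23)c2c1C(OCCc1ccccc1)CC(=O)N2` gives 3 nM. Among these three, compound 3 holds the second highest number: the change was a 2.7-fold lower number from compound 1 to compound 3 (0.43 log units; beyond the scatter), and the change was a 3.0-fold higher number from compound 2 to compound 3 (0.48 log units; beyond the scatter), so compound 3 sits nearer to compound 1 than to compound 2.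

Compound 4 `COc1ccc(CCOC2CC(=O)Nc3c2c(C)nn3-c2ncnc3nc[nH]c23)cc1` differs from compound 3 by methoxy in place of hydrogen on an aromatic carbon. None of the three measured steps concerns a methoxy group on an aromatic carbon. Going by the values given here, the steps of an 8.0-fold lower number from compound 1 to compound 2 (0.90 log units; beyond the scatter) and a 2.7-fold lower number from compound 1 to compound 3 (0.43 log units; beyond the scatter) both swap a saturated chain for an aromatic group, and the step of a 3.0-fold higher number from compound 2 to compound 3 (0.48 log units; beyond the scatter) alters the aromatic group together with its link to the oxygen, so no measured step isolates a single substituent on the six-membered aromatic ring of carbon only. The expected step is therefore small, no change at the digits printed from compound 3 to compound 4 (within the scatter), and is not expected to fall clearly beyond the scatter in either direction. Compound 4 is estimated to give 3 nM in this assay, with a plausible range from 1 nM to 10 nM.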

Compound 4, half-maximal effective concentration: 2 nM
Beside the measured number, compound 4's estimate is 1.5-fold (0.18 log units) above it; the range from low to high includes it.
By their numbers in this assay, from the lowest: compounds 2, 4 and 3 (each within the scatter of the next, the first and the last beyond it); then compound 1.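

Methoxy in place of hydrogen on an aromatic carbon, para to a large group, is the first change in this series confined to the six-membered aromatic ring, and a 1.5-fold lower number from compound 3 to compound 4 (0.18 log units; within the scatter) shows that in this assay this position accepts methoxy with no difference beyond the scatter. Compound 4 also stays within the scatter of the fluorinated compound, with a 2.0-fold higher number from compound 2 to compound 4 (0.30 log units; within the scatter), while the 2-(4-methoxyphenyl)ethyl group keeps the separation from the saturated chain of compound 1, with a 4.0-fold lower number from compound 1 to compound 4 (0.60 log units; beyond the scatter) lying beyond the scatter. No measurement shown here accounts for the small size of the methoxy step, so the result describes only what this position accepts.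

The compounds shown leave open whether this aromatic carbon would accept a group of a different kind, such as an amine, a carboxylic acid or a longer alkoxy chain, with the same small effect. They also leave open how methoxy would behave on another carbon of the same ring, or on the ring of the shorter 4-methoxybenzyl side chain.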